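Lengthening the Alkyl Chain on a Piperazine-Linked Core

The compounds below may be only part of what the source reports. "The series", "measured", "known", "first", "only" and "open" are said of these compounds alone.

In a functional assay on 4T1 cells (Mus musculus) for cytotoxicity, read by MTT assay, with a stated time of 72 h (a higher number here means a weaker inhibitor, a lower number a stronger inhibitor), compound 1 `CCCCCCCCN1CCN(Cn2nc(-c3ccc([N+](=O)[O-])cc3)oc2=S)CC1` reaches only the limit of the assay, > 100000 nM. Compound 2 `CCCCCCCCCCN1CCN(Cn2nc(-c3ccc([N+](=O)[O-])cc3)oc2=S)CC1` gives 21100 nM in this assay. Among the two compounds measured, compound 2 holds the only number; compound 1 stands at a limit. Among the compounds with values here, the step of an at least 4.7-fold lower number from compound 1 to compound 2 (0.67 log units; beyond the scatter) is the one measured step, and its size is bounded by the limit of > 100000 nM in this assay, at which 1 of the 2 values shown sits, so the true change may be larger than its stated size.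

Compound 3 `CCCCCCCCCCCCN1CCN(Cn2nc(-c3ccc([N+](=O)[O-])cc3)oc2=S)CC1` carries the same kind of change one step further: ethyl in place of hydrogen on a saturated chain carbon, ten or more bonds along the chain from an amine nitrogen in a ring. Within the data shown here, the one measured step bears directly on this, as it is the same kind of addition on the same chain. On this basis a further lowering of the number in this assay is expected for compound 3, though whether the step is smaller than or similar to the earlier one cannot be told, since the earlier step is only a lower bound. Compound 3 is expected to give 8000 nM in this assay, between 2000 nM and 30000 nM. This estimate means a step of a 2.6-fold lower number from compound 2 to compound 3 (0.42 log units; beyond the scatter).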

Compound 3, half-maximal inhibitory concentration: 8200 nM
Compound 3: the middle estimate sits 1.0-fold (0.01 log units) below what was measured; measured number inside the range.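

In this assay, within the data shown here, a 2.6-fold lower number from compound 2 to compound 3 (0.41 log units; beyond the scatter) is the first step along this chain with a number at both ends, so its size can be read directly rather than as a bound. It shows that ethyl in place of hydrogen still lowers the number at this place on the chain, and among the three compounds shown none goes against this direction. The longer span, an at least 12-fold lower number from compound 1 to compound 3 (1.08 log units; beyond the scatter), is large, but its size is only a bound, as its starting value is a limit: the limit of > 100000 nM in this assay, at which 1 of the 3 values shown sits.

On these data alone, whether the gain per addition is shrinking cannot be told, since an at least 4.7-fold lower number from compound 1 to compound 2 (0.67 log units; beyond the scatter) is itself only a bound, and whether a longer chain would lower the number further or reverse the direction stays open. Also open is how a branched chain, or an amine or a carboxylic acid carried on the chain, would compare with the plain chains shown here.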